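This account rests on a few compounds, and the source may have more. Where it says the series, first, only, none or still open, it means among the compounds named here.

Measured compounds:
compound 1 `COc1ccc2nc(C)cc(OCC(=O)Nc3cc(C)ccc3C)c2c1` — > 100000 nM
compound 2 `COc1ccc2nc(C)cc(OCC(=O)Nc3ccncn3)c2c1` — > 100000 nM

In a toxicity assay on HepG2 cells (Homo sapiens) for inhibition, read by CellTiter-Glo, with a stated time of 48 h (a higher number here means a weaker inhibitor, a lower number a stronger inhibitor), compound 1 gives > 100000 nM, which is a limit of the assay and not a number. In this assay compound 2 gives > 100000 nM, again a limit. The step that the two limits leave unreadable from compound 1 to compound 2 is therefore unreadable, since both ends sit at the limit of > 100000 nM in this assay, at which 2 of the 2 values shown sit. Compound 2 thus stands at the limit of this assay, with no number to place it against anything.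

Compound 3 `COc1ccc2nc(C)cc(OCC(=O)Nc3nccs3)c2c1` differs from compound 2 by 1,3-thiazol-2-yl in place of pyrimidin-4-yl on an amide-type nitrogen. Going by the values given here, the only measured step at the amide-type nitrogen, a step that the two limits leave unreadable from compound 1 to compound 2, has no readable size, so it gives neither a direction nor a magnitude for this assay. A step of a number no higher from compound 2 to compound 3 (the limit leaves the size open) is expected, none beyond the scatter, and a limit rather than a number is the likelier outcome. Compound 3 is estimated at 100000 nM, with a range from 40000 nM to 300000 nM.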

Compound 3, half-maximal inhibitory concentration: > 100000 nM
Compound 3 ended at the assay's limit (the forecaster's own chance of this, stated with the estimate: 80%); the middle value sits exactly at the limit.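

In this assay compound 3 gives > 100000 nM as a limit of the assay and not a number. Going by these compounds alone, no step among compound 1, compound 2 and compound 3 can be read: the limit of > 100000 nM in this assay, at which 3 of the 3 values shown sit.

In this assay the compounds shown leave open how 2,5-dimethylphenyl, pyrimidin-4-yl and 1,3-thiazol-2-yl on an amide-type nitrogen rank against one another.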